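This account rests on a few compounds, and the source may have more. Where it says the series, first, only, none or still open, it means among the compounds named here.

In a functional assay on THP-1 cells (Homo sapiens) for cytotoxicity, read by MTT assay, with a stated time of 24 h (on this read-out higher numbers stand for weaker inhibition and lower numbers for stronger inhibition), the measured compounds stand as follows:

- compound 1, `COc1cc(/C=C2\CN(C)C/C(=C\c3ccccc3F)C2=O)cc(OC)c1`, gives 1170 nM
- compound 2, `CN1C/C(=C\c2ccc(C#N)cc2)C(=O)/C(=C/c2ccccc2F)C1`, gives 810 nM
- compound 3, `COc1cc(/C=C2\CN(C)C/C(=C\c3ccc(F)cc3)C2=O)cc(OC)c1`, gives 5040 nM

Compound 1 and compound 3 differ by one change, (4-fluorophenyl in place of 2-fluorophenyl on a double-bonded chain carbon bound to a double-bonded ring carbon), and in this assay that change gave a 4.3-fold higher number from compound 1 to compound 3 (0.63 log units; beyond the scatter). Compound 2 carries the lowest number of the three, but its gap to compound 1 lies within the scatter, so no order between those two is claimed; its gap to compound 3 lies beyond the scatter. The difference between the core of compound 1 and the core of compound 2 is not broken down here.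

Compound 4, `CN1C/C(=C\c2ccc(F)cc2)C(=O)/C(=C/c2ccc(C#N)cc2)C1`, is not yet measured. It differs from compound 2 by 4-fluorophenyl in place of 2-fluorophenyl on a double-bonded chain carbon bound to a double-bonded ring carbon, the same change as from compound 1 to compound 3, at the same place. For the measured compounds named here, with only that one measured step to rest on, the expected step in this assay is a 4.2-fold higher number from compound 2 to compound 4 (0.62 log units; beyond the scatter), set beside a 4.3-fold higher number from compound 1 to compound 3 (0.63 log units; beyond the scatter). For compound 4 the expected value is therefore 3400 nM, estimated to lie between 1500 nM and 8000 nM.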

Compound 4, half-maximal inhibitory concentration: 5030 nM
Estimate against measurement, compound 4: 1.5-fold (0.17 log units) below; measured number inside the range.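

In this assay, 4-fluorophenyl in place of 2-fluorophenyl gave a 6.2-fold higher number from compound 2 to compound 4 (0.79 log units; beyond the scatter), and this step matches the earlier one in direction and, within the scatter, in size: the same change on two cores in this assay, a 4.3-fold higher number (0.63 log units; beyond the scatter) from compound 1 to compound 3 and a 6.2-fold higher number (0.79 log units; beyond the scatter) from compound 2 to compound 4, 1.4-fold (0.16 log units) apart, within the scatter of two such steps The change therefore carried from the core of compound 1 to the core of compound 2 with no difference that these data can resolve, and on both cores the 4-fluorophenyl compound has the higher number. For the compounds shown here, this rests on only two matched pairs, so it does not show that the step would hold on any other core, and it gives no explanation for the step.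

The compounds shown leave open whether 3-fluorophenyl or 2-chlorophenyl at this place would follow the same trend as 2-fluorophenyl or 4-fluorophenyl. They also leave open whether the step would survive on a core carrying an amine or a carboxylic acid on the other aryl group.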